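Methoxy for amino on the aryl group of compound 3

The source may hold more compounds than are shown below. What is called first, only, known or untested is meant among the compounds shown, and "the series" means these compounds.

Measured in a functional assay on MCF7 cells (Homo sapiens) for cytotoxicity, read by MTT assay, with a stated time of 48 h; a higher number here means a weaker inhibitor, a lower number a stronger inhibitor:
Compound 1, `CC(=O)Nc1cccc(-c2cnc3[nH]cc(-c4ccncc4)c3c2)c1`: compound 1 gives 9100 nM.
Compound 2, `CC(=O)Nc1cc(N)cc(-c2cnc3[nH]cc(-c4ccncc4)c3c2)c1`: compound 2 gives a limit of the assay, > 30000 nM.
Compound 3, `Nc1cccc(-c2cnc3[nH]cc(-c4ccncc4)c3c2)c1`: compound 3 gives 2300 nM.

Compound 3 holds the lowest of the two numbers obtained; the nearest is compound 1, and the step of a 4.0-fold lower number from compound 1 to compound 3 (0.60 log units; beyond the scatter) lies beyond the scatter. Within the data shown here, the only other value, that of compound 2, is a limit, and the step of an at least 13-fold lower number from compound 2 to compound 3 (1.11 log units; beyond the scatter) is therefore also only a bound. The remaining step, an at least 3.2-fold higher number from compound 1 to compound 2 (0.51 log units; beyond the scatter), is likewise a bound.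

Compound 4, `COc1cccc(-c2cnc3[nH]cc(-c4ccncc4)c3c2)c1`, differs from compound 3 by methoxy in place of amino on an aromatic carbon. Among the measured compounds shown here, none of the measured steps swaps one small group for another at this carbon; they remove or add groups entirely, so they bear on the new change only loosely. The loss of the amino group, which in compound 3 accompanies the lowest number, is expected to cost some potency, so for compound 4 a step of a 2.2-fold higher number from compound 3 to compound 4 (0.34 log units; beyond the scatter) in this assay is expected, with a higher number. Compound 4 is therefore estimated at 5000 nM, within 1500 nM to 16000 nM.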

Compound 4, half-maximal inhibitory concentration: 11700 nM
Estimate against measurement, compound 4: 2.3-fold (0.37 log units) below; the range from low to high includes it.
By their numbers in this assay, from the lowest: compound 3; then compounds 1 and 4 (each within the scatter of the next). At a limit, above all of these: compound 2.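

In this assay, among these compounds, methoxy in place of amino gives a 5.1-fold higher number from compound 3 to compound 4 (0.71 log units; beyond the scatter), the first exchange of one small group for another at this aromatic carbon, and the lower number of the amino compound does not carry over to the methoxy compound. Methoxy and acetamido at this carbon cannot be told apart, with a 1.3-fold higher number from compound 1 to compound 4 (0.11 log units; within the scatter), so among these three groups only amino stands apart here. What lies behind the exchange of amino for methoxy is not settled by any measurement available here.

On these data alone, it remains open whether the lower number is particular to the unsubstituted amino group or would also appear with a hydroxyl, a methylamino or an aminomethyl group at this carbon. As far as these compounds go, it is also open whether amino would give the same result at another carbon of this aromatic ring.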